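Swapping Furan for Pyrimidine on a Cyanophenyl Amine

The compounds below may be only part of what the source reports. "The series", "measured", "known", "first", "only" and "open" are said of these compounds alone.

Of the compounds shown here, three here have been tested in a functional assay on PC-3 cells (Homo sapiens) for antiproliferative activity, read by CCK-8 assay, with a stated time of 6 days (on this read-out higher numbers stand for weaker inhibition and lower numbers for stronger inhibition), and a fourth awaits its measurement. Compound 1 `N#Cc1ccc(N2CCc3cc(-c4cnc5ccccc5c4)ccc3C2)cc1C(F)(F)F` gives 25100 nM. Compound 3 `CCN(c1ccc(C#N)c(Cl)c1)c1cc(-c2cnc3ccccc3c2)ccc1C` gives 3570 nM. Compound 2 `CCN(c1ccc(C#N)c(Cl)c1)c1cc(-c2ccoc2)ccc1C` returns only > 30000 nM, which is a limit of the assay rather than a number, so compound 2 sits at the limit of > 30000 nM in this assay, at which 1 of the 3 values shown sits.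

Compound 4 `CCN(c1ccc(C#N)c(Cl)c1)c1cc(-c2cncnc2)ccc1C` is built from compound 2 with one change: pyrimidin-5-yl in place of furan-3-yl on an aromatic carbon. Among the measured compounds shown here, no measured pair in this set shows what such a swap does, so the size of the step is a judgement. A modest gain in inhibition, staying within or just beyond the usual scatter, is expected as an at least 1.5-fold lower number from compound 2 to compound 4 (0.17 log units; that floor lies within the scatter). Compound 4 is estimated to give 20000 nM, with an expected range from 6000 nM to 60000 nM.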

Compound 4, half-maximal inhibitory concentration: > 30000 nM
Compound 4 gave a limit, no number; the forecaster's own chance of this, stated with the estimate: 35%; middle value at least 1.5-fold (0.17 log units) away from the limit.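

Compound 2 and compound 4 both end at a limit of the assay rather than a number, so no step can be read between them: the limit of > 30000 nM in this assay, at which 2 of the 4 values shown sit. Going by these compounds, whether pyrimidin-5-yl in place of furan-3-yl changes inhibition at all remains open.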